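The source may report more compounds than this note shows. Statements on the series, on what has been measured and on what is new or still open speak of the compounds shown alone.

Measured so far:
Compound 1, `CC1(C)N=C(N)N=C(N)N1c1cccc(F)c1`: 5.24
Compound 2, `CC1(C)N=C(N)N=C(N)N1c1cccc(OCCOc2ccccc2)c1`: 5.02

Both compounds share the same core and differ only in the group attached to the aromatic ring. In a functional assay on L5178Y cells (Mus musculus) (a lower number here means a less potent compound, a higher number a more potent compound, by a factor of ten per unit of this negative logarithm), compound 1 gives 5.24, and in this assay compound 2 gives 5.02. Compound 2 has the lower of the two numbers, but the gap to compound 1 lies within the scatter of repeated measurements, so the two values cannot be told apart. It is worth noting that the two groups on the aromatic ring are very different in size, yet the two values are this close.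

Compound 3, `CCCCOc1cccc(N2C(N)=NC(N)=NC2(C)C)c1`, is the next compound. It differs from compound 2 by ethyl in place of phenoxy on a saturated chain carbon, two bonds along the chain from an oxygen on an aromatic ring. Among the measured compounds shown here, no step between measured compounds is known, so there is no direct guide to the size of this change. Since the two measured compounds, with very different groups at that position, gave values within the scatter of each other, the step from compound 2 to compound 3 is expected to be small, a number 0.08 log units higher from compound 2 to compound 3 (within the scatter), not beyond the scatter in either direction. Compound 3 is therefore estimated at 5.1, with a likely range from 4.6 to 5.6.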

Compound 3, logarithm of the reciprocal of the active concentration, log(1/C): 5.95
The estimate for compound 3 lay 0.85 log units below the measured number; measured number outside the range, above it.
By their numbers in this assay, from the lowest: compounds 2 and 1 (each within the scatter of the next); then compound 3.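

In this assay, ethyl in place of phenoxy on a saturated chain carbon, two bonds along the chain from an oxygen on an aromatic ring, gives a number 0.93 log units higher from compound 2 to compound 3 (beyond the scatter) and shows that the end of this chain matters, something the close values of compound 1 and compound 2 had hidden. Butoxy in place of fluoro on an aromatic carbon gives a number 0.71 log units higher from compound 1 to compound 3 (beyond the scatter) and so places compound 3 clear of both earlier compounds, not merely of the one it most resembles. Compound 2 also carries a chain on that oxygen, so a chain there is not enough on its own, and what stands at the chain end makes the difference. Nothing at hand explains why the ethyl end gives the higher number.

On these data alone, it remains open whether a shorter chain such as propoxy or a longer one such as hexyloxy would give a higher or a lower number than butoxy. As far as these compounds go, it is equally open how an amine or a carboxylic acid at the end of the chain would compare.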